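Replacing Carboxy with Phenoxy in a Cytotoxicity Series

The source may report more compounds than this note shows. Statements on the series, on what has been measured and on what is new or still open speak of the compounds shown alone.

Compound 1 `O=C1Nc2ccccc2/C1=N/NC(=S)Nc1ccc(Cl)cc1`: 13400 nM
Compound 2 `O=C1Nc2ccccc2/C1=N/NC(=S)Nc1ccc(C(=O)O)cc1`: > 50000 nM
Compound 3 `O=C1Nc2ccccc2/C1=N/NC(=S)Nc1ccc(Oc2ccccc2)cc1`: not yet measured

In a functional assay on KB 3-1 cells (Homo sapiens) for cytotoxicity, read by MTT assay, with a stated time of 72 h (a higher number here means a weaker inhibitor, a lower number a stronger inhibitor), compound 2 gives only a limit, > 50000 nM, and not a number. Compound 1 gives 13400 nM in this assay.

Compound 3 keeps the shared core of compound 2 and changes one group, with phenoxy in place of carboxy on an aromatic carbon, para to a large group: phenoxy in place of carboxy on an aromatic carbon.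

Within the data shown here, one measured step bears on this change. It is an at least 3.7-fold higher number from compound 1 to compound 2 (0.57 log units; beyond the scatter), which brought in the same carboxy at the same place. Compound 3 loses that carboxy again, so a step of similar size in the opposite direction is expected from the evidence of an at least 3.7-fold higher number from compound 1 to compound 2 (0.57 log units; beyond the scatter).

The expected change is an at least 5.5-fold lower number from compound 2 to compound 3 (0.74 log units; beyond the scatter), towards a lower number in this assay.

The estimate for compound 3 is 9000 nM, with an expected range of 2500 nM to 30000 nM.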

Compound 3, half-maximal inhibitory concentration: 5720 nM
The estimate for compound 3 lay 1.6-fold (0.20 log units) above the measured number; measured number inside the range.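

Among these compounds, at this aromatic carbon, para to a large group, the earlier compounds showed only a loss on going from chloro to carboxy; phenoxy now shows that the same place can carry a group with its own six-membered aromatic ring, with an at least 8.7-fold lower number from compound 2 to compound 3 (0.94 log units; beyond the scatter) in this assay. Phenoxy also goes beyond chloro, with a 2.3-fold lower number from compound 1 to compound 3 (0.37 log units; beyond the scatter), which makes compound 3 the most potent of the three in this assay. The full size of the first step remains unknown, because compound 2 gives only a limit and not a number: the limit of > 50000 nM in this assay, at which 1 of the 3 values shown sits.

The compounds shown leave open whether the lower number with phenoxy goes with its oxygen or with its aromatic ring, which a methoxy group or a benzyl group at the same carbon would help to separate. Going by these compounds, whether an amine at this place would fall nearer to carboxy or to chloro also stays open.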